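The compounds below may be only part of what the source reports. "The series", "measured", "known", "first", "only" and "open" are said of these compounds alone.

Measured compounds:
- compound 1 `C[Se]/C(=N\C(=O)c1cc2ccccc2s1)NC(=O)c1cc2ccccc2s1` — 94000 nM in a functional assay on PC-3 cells (Homo sapiens) for cytotoxicity, read by MTT assay, with a stated time of 72 h; a lower number here means that less compound is tolerated, a higher number that more compound is tolerated
- compound 2 `CS/C(=N\C(=O)c1cc2ccccc2s1)NC(=O)c1cc2ccccc2s1` — 72600 nM in this assay
- compound 3 `C[Se]/C(=N\C(=O)c1cnc2ccccc2c1)NC(=O)c1cnc2ccccc2c1` — > 100000 nM in this assay

Compound 1 and compound 2 share one core and differ at a single site: a group of 2 heavy atoms (1 carbon, 1 sulfur; no ring) in place of a group of 2 heavy atoms (1 carbon, 1 selenium; no ring), on a carbon with a double bond to nitrogen. The step in this assay is a 1.3-fold lower number from compound 1 to compound 2 (0.11 log units; within the scatter), so the two values give no ground to speak of one as better tolerated than the other.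

Compound 3 carries the selenium-bearing group on a different core. The value for compound 3 in this assay is a limit of the assay, not a number; it sits at the limit of > 100000 nM in this assay, at which 1 of the 3 values shown sits. The difference between the core of compound 3 and the core of compound 1 is not broken down here.

Compound 4 `CS/C(=N\C(=O)c1cnc2ccccc2c1)NC(=O)c1cnc2ccccc2c1` is not yet measured in this assay. It stands to compound 3 as compound 2 stands to compound 1: a group of 2 heavy atoms (1 carbon, 1 sulfur; no ring) in place of a group of 2 heavy atoms (1 carbon, 1 selenium; no ring), on a carbon with a double bond to nitrogen. The place lines of the two changes read the same word for word, so this is the same kind of change made on the other core.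

For compound 4 the step in this assay is expected to be a step that the limit leaves unreadable from compound 3 to compound 4, resting on the one earlier occurrence of this change, where compound 1 to compound 2 gave a 1.3-fold lower number from compound 1 to compound 2 (0.11 log units; within the scatter), and on the fact that compound 3 itself shows only a limit. Compound 4 is therefore estimated at 120000 nM, with a range of 55000 nM to 300000 nM, and there is a fair chance that the assay will again report only a limit rather than a number.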

Compound 4, concentration lethal to 50% of the cells: > 100000 nM
Compound 4: a limit, no number; the forecaster's own chance of this, stated with the estimate: 65%; the middle value does not contradict the limit.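

No step can be read from compound 3 to compound 4 in this assay: each of the two values is a limit of the assay, not a number. Both compounds sit at the same place: the limit of > 100000 nM in this assay, at which 2 of the 4 values shown sit.

The compounds shown leave open whether methylsulfanyl in place of the selenium-bearing group makes any difference to the value on the core of compound 3.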